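Cytotoxicity in HeLa Cells for a Fourth Analogue

This account rests on a few compounds, and the source may have more. Where it says the series, first, only, none or still open, it means among the compounds named here.

Compound 1 `N#CCCCn1c(Cn2c(=O)n(-c3ccc(C(=O)NC4CC4)cc3)c3ccncc32)cc2cc(Cl)ccc21` was tested in an ADME assay on HeLa cells (Homo sapiens) for cytotoxicity, read by ATP content, with a stated time of 3 days; a higher number here means that more compound is tolerated, a lower number that less compound is tolerated. In this assay compound 1 reaches only the limit of > 50000 nM, a ceiling of the measurement rather than a number. Compound 2 `CS(=O)(=O)CCCn1c(Cn2c(=O)n(C3CC3)c3ccncc32)cc2cc(F)ccc21` likewise gives a limit of > 50000 nM in this assay. Compound 3 `CC(C)(C)n1c(=O)n(Cc2cc3cc(Cl)ccc3n2CCCS(C)(=O)=O)c2cnccc21` also sits at the limit of > 50000 nM. Thus compound 1 stands alongside the other two at the same ceiling, as the limit of > 50000 nM in this assay, at which 3 of the 3 values shown sit, states for all three values. Compound 4 `COc1ccc(-n2c(=O)n(Cc3cc4cc(Cl)ccc4n3CCCC#N)c3cnccc32)c(C)c1` has not yet been measured in this assay. It differs from compound 1 in one place: 4-methoxy-2-methylphenyl in place of 4-(cyclopropylcarbamoyl)phenyl on an aromatic nitrogen. Among the measured compounds shown here, no step between measured compounds is available to calibrate such a change, so the expectation for compound 4 rests on (the limit of > 50000 nM in this assay, at which 3 of the 3 values shown sit), the common outcome of compounds 1, 2 and 3. Compound 4 is expected to be tolerated similarly, with an expected step that the limit leaves unreadable from compound 1 to compound 4 that does not go beyond the usual scatter. For compound 4 the estimated value in this assay is 60000 nM, with a range from 30000 nM to 150000 nM, and most likely the assay will again report only a limit.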

Compound 4, half-maximal cytotoxic concentration: > 50000 nM
Compound 4 ended at the assay's limit (the forecaster's own chance of this, stated with the estimate: 85%); the middle value does not contradict the limit.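

In this assay, among the compounds shown here, compound 1 and compound 4 both end at a limit of the measurement, so no step between them can be read. The compounds shown leave open where cytotoxicity would begin for any of them, as all share one ceiling: the limit of > 50000 nM in this assay, at which 4 of the 4 values shown sit.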